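This account rests on a few compounds, and the source may have more. Where it says the series, first, only, none or still open, it means among the compounds named here.

Compound 1: `CCC(C)(C)Cc1c[nH]c(CCc2ccc(-c3cccc(C)n3)cc2)n1` — 6.3 nM
Compound 2: `CCC(C)(C)Cc1c[nH]c(CCc2ccc(-n3ncnn3)cc2)n1` — 205 nM
Compound 3: `CCC(C)(C)Cc1c[nH]c(CCc2ccc(-c3cnccn3)cc2)n1` — 51 nM

In an in vitro assay on CHO cells for displacement of a labelled ligand from Bombesin receptor subtype-3 (Homo sapiens), read by scintillation counting, with a stated time of 2 h (a lower number here means a stronger inhibitor, a higher number a weaker inhibitor), compound 3 stands second highest of the three numbers; its nearest neighbour is compound 2, with a 4.0-fold lower number from compound 2 to compound 3 (0.60 log units; beyond the scatter), and its furthest is compound 1, with an 8.1-fold higher number from compound 1 to compound 3 (0.91 log units; beyond the scatter). The unmeasured compound 4 is `CCC(C)(C)Cc1c[nH]c(CCc2ccc(-c3cccc(N)n3)cc2)n1`. The change from compound 3 is 6-aminopyridin-2-yl in place of pyrazin-2-yl on an aromatic carbon. For the measured compounds named here, two measured steps bear on it: the step from compound 1 to compound 3 shows that 6-methylpyridin-2-yl gives a lower number than pyrazin-2-yl at this place, and the step from compound 2 to compound 3 shows that pyrazin-2-yl in turn gives a lower number than 2H-tetrazol-2-yl. Since 6-aminopyridin-2-yl shares the pyridin-2-yl ring of compound 1 and carries its own substituent there, a step down from compound 3 is expected in this assay, estimated at a 4.3-fold lower number from compound 3 to compound 4 (0.63 log units; beyond the scatter), though the amino group in place of methyl leaves its exact size uncertain. Compound 4 is therefore estimated at 12 nM, within a range of 3 nM to 50 nM.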

Compound 4, half-maximal inhibitory concentration: 7.3 nM
For compound 4 the middle estimate is 1.6-fold (0.22 log units) above the measured one; the measured number falls inside the stated range.
By their numbers in this assay, from the lowest: compounds 1 and 4 (each within the scatter of the next); then compound 3; then compound 2.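

With a 7.0-fold lower number from compound 3 to compound 4 (0.84 log units; beyond the scatter) and a 28-fold lower number from compound 2 to compound 4 (1.45 log units; beyond the scatter) in this assay as the result, the 6-aminopyridin-2-yl group joins 6-methylpyridin-2-yl clear of both pyrazin-2-yl and 2H-tetrazol-2-yl at this place on the ring. With a 1.2-fold higher number from compound 1 to compound 4 (0.06 log units; within the scatter) in this assay as the last step, amino and methyl cannot be told apart here, so the low numbers are not tied to methyl alone, and the hydrogen-bond donor of 6-aminopyridin-2-yl carries no visible cost. The compounds offer no evidence on why these groups rank as they do.

Still open, as far as these compounds go, is whether the plain pyridin-2-yl ring, with no group on it, would read like these two, which would show if the amino or methyl group matters at all. Also open, from the compounds shown here alone, is how a larger group such as methoxy or a carboxylic acid would fare on that ring.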